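Shared core series: the step from compound 3 to compound 4

The source may hold more compounds than are shown below. What is called first, only, known or untested is meant among the compounds shown, and "the series" means these compounds.

Among the measured compounds shown here, compound 3 `CC1CCN(c2ccc(Nc3nccc(-c4ccncc4)n3)cc2)CC1` gives 600 nM in a functional assay for inhibition, with Homo sapiens as the target (a higher number here means a weaker inhibitor, a lower number a stronger inhibitor), the lowest of the three numbers measured so far. Compound 2 `CN(C)c1ccc(Nc2nccc(-c3cccs3)n2)cc1` gives 900 nM in this assay, which lies within the scatter of compound 3, so no order between these two is claimed. Compound 1 `CN(C)c1ccc(Nc2nccc(-c3ccco3)n2)cc1` gives 1900 nM in this assay, beyond the scatter from compound 3. For the measured compounds named here, the only measured single step, a 2.1-fold lower number from compound 1 to compound 2 (0.32 log units; beyond the scatter), concerns thiophen-2-yl in place of furan-2-yl and not the group changed here. Compound 4 `CN(C)c1ccc(Nc2nccc(-c3ccncc3)n2)cc1` differs from compound 3 as follows: dimethylamino in place of 4-methylpiperidin-1-yl on an aromatic carbon. Going by the values given here, no measured pair isolates this change. Compound 1 carries dimethylamino and gives 1900 nM. Compound 2 also carries dimethylamino and gives 900 nM. Compound 3 alone carries 4-methylpiperidin-1-yl, with a different group elsewhere, so the two differences are confounded. Compound 4 is therefore expected to sit close to its dimethylamino relatives, which means an expected step of a 1.7-fold higher number from compound 3 to compound 4 (0.22 log units; within the scatter), at or just beyond the scatter. The estimate for compound 4 in this assay is 1000 nM, with a range from 400 nM to 2500 nM.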

Compound 4, half-maximal inhibitory concentration: 3700 nM
Compound 4: middle estimate off by 3.7-fold (0.57 log units), on the low side; measured number outside the range, above it.
By their numbers in this assay, from the lowest: compounds 3 and 2 (each within the scatter of the next); then compounds 1 and 4 (each within the scatter of the next).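

In this assay, the change on the aromatic carbon para to a large group is now isolated with pyridin-4-yl held constant (a 6.2-fold higher number from compound 3 to compound 4 (0.79 log units; beyond the scatter)), so the low number of compound 3 goes with 4-methylpiperidin-1-yl and not with pyridin-4-yl. With dimethylamino held constant, thiophen-2-yl stands apart from pyridin-4-yl (a 4.1-fold higher number from compound 2 to compound 4 (0.61 log units; beyond the scatter)), whereas furan-2-yl and pyridin-4-yl are not separated (a 1.9-fold higher number from compound 1 to compound 4 (0.29 log units; within the scatter)). No measurement at hand explains the size of these steps.

Dimethylamino and 4-methylpiperidin-1-yl differ both in the ring and in heavy-atom count, so it remains open whether the ring alone or its methyl group matters; piperidin-1-yl or morpholin-4-yl at this place would separate these. Also open, going by these compounds, is whether 4-methylpiperidin-1-yl gives a similar step when thiophen-2-yl replaces pyridin-4-yl.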